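Aryl variation on the shared core and HEL cell cytotoxicity

The compounds below may be only part of what the source reports. "The series", "measured", "known", "first", "only" and "open" are said of these compounds alone.

Compound 1 `Cc1cc(-c2ccc(C#N)cc2)cn2c(CSCCc3ccccc3)cnc12` carries a 4-cyanophenyl on the shared core. In an ADME assay on HEL cells (Homo sapiens) for cytotoxicity, with a stated time of 3 days (on this read-out lower numbers stand for higher toxicity in this test and higher numbers for lower toxicity in this test), compound 1 gives 10.6 ug/mL. Compound 3 `COc1ccc(-c2cc(C)cn3c(CSCCc4ccccc4)cnc23)cc1` gives 19.6 ug/mL in this assay, which lies within the scatter of the number for compound 1, so no order between the two is claimed. Compound 2 `Cc1cc(-c2cccs2)c2ncc(CSCCc3ccccc3)n2c1` gives only > 50 ug/mL in this assay, and this is a limit of the test rather than a number; it is the point noted as the limit of > 50 ug/mL in this assay, at which 1 of the 3 values shown sits.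

Within the data shown here, the only measured step at this position is an at least 2.5-fold lower number from compound 2 to compound 3 (0.40 log units; beyond the scatter). It exchanges the aryl for another aryl, as the step to compound 4 does, but neither group involved appears in compound 4 `Cc1cc(-c2cccc(O)c2)cn2c(CSCCc3ccccc3)cnc12`, so it bears on the new step only loosely.

Compound 4 differs from compound 1 as follows: 3-hydroxyphenyl in place of 4-cyanophenyl on an aromatic carbon. Both aryl-bearing analogues measured so far, compound 1 and compound 3, sit close together in this assay, so for compound 4 a step of a 1.3-fold higher number from compound 1 to compound 4 (0.12 log units; within the scatter) is expected, within the scatter. The value expected for compound 4 in this assay is 14 ug/mL, with a range from 6 ug/mL to 35 ug/mL.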

Compound 4, half-maximal cytotoxic concentration: 50 ug/mL
Compound 4: the middle estimate sits 3.6-fold (0.55 log units) below what was measured; measured number outside the range, above it.
By their numbers in this assay, from the lowest: compounds 1 and 3 (each within the scatter of the next); then compound 4.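

Exchanging the aryl group on the shared core is not without consequence in this assay: the 3-hydroxyphenyl of compound 4 gives a 4.7-fold higher number from compound 1 to compound 4 (0.67 log units; beyond the scatter), whereas the 4-cyanophenyl of compound 1 and the 4-methoxyphenyl of compound 3 had stayed within the scatter of each other. Among the groups shown at this position, 3-hydroxyphenyl is the only one with a hydrogen-bond donor, and it is also the only phenyl group not substituted at its 4-position, so this single step ties the higher number to neither feature alone. Compound 2 remains a limit and not a number, so its order against compound 4 cannot be read: the limit of > 50 ug/mL in this assay, at which 1 of the 4 values shown sits.

Open, from the compounds shown here alone, is whether the hydroxyl itself or its place on the phenyl ring goes with the higher number; 4-hydroxyphenyl and 3-methoxyphenyl would separate the two. Also open, going by these compounds, is whether another donor-bearing group, such as 3-aminophenyl, or a carboxylic acid on the same ring, would behave like the 3-hydroxyphenyl in this assay.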